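A few compounds are considered here, and "the series" means these few. Any claim that something is new, unique, unknown or untested is made for them only; others in the source may bear on it.

Compound 1 `Cc1cn([C@@H]2O[C@H](CO)[C@@H](CO)[C@H]2O)c(=O)[nH]c1=O` reaches only the assay limit in a functional assay on CCRF-CEM cells (Homo sapiens) for antiproliferative activity, with a stated time of 72 h (on this read-out lower numbers stand for an effect already at smaller amounts and higher numbers for an effect only at larger amounts of compound), giving > 100 uM.
Compound 2 `Cc1cn([C@@H]2O[C@H](CO)[C@@H](CF)[C@H]2O)c(=O)[nH]c1=O` likewise stops at a limit in this assay, giving > 100 uM.
Compound 3 `Cc1cn([C@@H]2O[C@H](CO)[C@@H](CN)[C@@H]2O)c(=O)[nH]c1=O` also gives a limit in this assay, > 100 uM.

Compound 2 therefore stands with all other measured values at the limit of > 100 uM in this assay, at which 3 of the 3 values shown sit, with no number of its own. Among the measured compounds shown here, the only step between measured compounds, a step that the two limits leave unreadable from compound 1 to compound 2, is unreadable because both ends are limits. Compound 4 `Cc1cn([C@H]2C[C@H](CF)[C@@H](CO)O2)c(=O)[nH]c1=O` differs from compound 2 by hydrogen in place of hydroxy on a saturated ring carbon. For the measured compounds named here, no measured step gives a readable size for such a change, so no shift beyond the scatter in this assay can be expected from the data. Compound 4 is thus estimated at 150 uM, with a range from 30 uM to 600 uM, meaning an expected step that the limit leaves unreadable from compound 2 to compound 4.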

Compound 4, concentration for half-maximal effect: > 100 uM
Compound 4: a limit, no number; the forecaster's own chance of this, stated with the estimate: 80%; the middle value is on the limit's open side.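

Among the compounds shown here, compound 4, like compound 2, gives only a limit, so no step between compound 2 and compound 4 can be read. The compounds shown leave open whether any change to the shared core brings a measurable effect in this assay.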